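The compounds below may be only part of what the source reports. "The series", "measured", "known", "first", "only" and "open" are said of these compounds alone.

Measured in a functional assay on DU-145 cells (Homo sapiens) for inhibition, read by trypan blue exclusion, with a stated time of 72 h; on this read-out lower numbers stand for stronger inhibition and higher numbers for weaker inhibition
compound 1 `COc1ccc(Nc2ncc3cc(S(=O)(=O)c4ccc(C)cc4)c(=O)n(C)c3n2)cc1` gives 100000 nM
compound 2 `Cn1c(=O)c(S(=O)(=O)c2ccccc2)cc2cnc(Nc3ccc4ncccc4c3)nc21` gives 50000 nM
compound 3 `Cc1ccc(S(=O)(=O)c2cc3cnc(Nc4cnc5[nH]ccc5c4)nc3n(C)c2=O)cc1` gives 25000 nM

Compound 3 sits at the low end of these numbers together with compound 2, the two lying within the scatter of each other, while compound 1 lies clearly apart from compound 3. The next change leads to compound 4 `Cc1ccc(S(=O)(=O)c2cc3cnc(Nc4ccc5ncccc5c4)nc3n(C)c2=O)cc1` and is a group of 10 heavy atoms (9 carbon, 1 nitrogen; one six-membered aromatic ring of carbon only, one six-membered aromatic ring with 1 hetero atom) in place of a group of 9 heavy atoms (7 carbon, 2 nitrogen; one five-membered aromatic ring with 1 hetero atom, one six-membered aromatic ring with 1 hetero atom), on a nitrogen on an aromatic ring on the shared core. The entering group is quinolin-6-yl, with 0 hydrogen-bond donors against 1 in the group that leaves.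

Among the measured compounds shown here, only one measured step bears directly on this position. It is a 4.0-fold lower number from compound 1 to compound 3 (0.60 log units; beyond the scatter), a modest step that brought in the group now leaving. Compound 2 also carries quinolin-6-yl on that nitrogen and differs from compound 4 elsewhere on the core. In this assay compound 2 gives 50000 nM. With that value as the nearest guide, no step beyond the scatter is expected. The expected change is a 1.4-fold higher number from compound 3 to compound 4 (0.15 log units; within the scatter), which is estimated to stay within the scatter. Compound 4 is estimated at 35000 nM, with an expected range from 12000 nM to 100000 nM.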

Compound 4, half-maximal inhibitory concentration: 10000 nM
Estimate against measurement, compound 4: 3.5-fold (0.54 log units) above; the measured number lies below the stated range.
By their numbers in this assay, from the lowest: compound 4; then compounds 3, 2 and 1 (each within the scatter of the next, the first and the last beyond it).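

In this assay, quinolin-6-yl on the nitrogen on an aromatic ring gives a 2.5-fold lower number from compound 3 to compound 4 (0.40 log units; beyond the scatter) and a 10-fold lower number from compound 1 to compound 4 (1.00 log units; beyond the scatter); with the rest of the core unchanged in each pair, the entering group, with 0 hydrogen-bond donors against 1 in the group that leaves, gives the lower number both times. The same group does not fix the number alone: methyl in place of hydrogen on an aromatic carbon, elsewhere on the molecule, gives a 5.0-fold lower number from compound 2 to compound 4 (0.70 log units; beyond the scatter). No measurement offered here explains either step.

Among the compounds shown here, the methyl-for-hydrogen change is seen only with quinolin-6-yl on the nitrogen, so its size with other groups there remains open. Also open, as far as these compounds go, is whether an amine or a carboxylic acid carried on quinolin-6-yl would move the number further from that of compound 4.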